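Amide aryl variation on a flavonol core against HeLa cells

The source may report more compounds than this note shows. Statements on the series, on what has been measured and on what is new or still open speak of the compounds shown alone.

Measured so far:
compound 1, `Cc1cccc(C(=O)Nc2cccc(-c3oc4cc(-c5ccc(F)cc5)ccc4c(=O)c3O)c2)c1`, 6650 nM
compound 2, `COc1cc(OC)cc(C(=O)Nc2cccc(-c3oc4cc(-c5ccc(F)cc5)ccc4c(=O)c3O)c2)c1`, 2700 nM

The two compounds share their core and differ only in the aryl group on the amide carbonyl. Going by the values given here, in a functional assay on HeLa cells (Homo sapiens) for antiproliferative activity, read by CCK-8 assay, with a stated time of 72 h (on this read-out lower numbers stand for stronger inhibition and higher numbers for weaker inhibition), compound 2 gives 2700 nM, the lower of the two numbers; the one step seen so far, a 2.5-fold lower number from compound 1 to compound 2 (0.39 log units; beyond the scatter), lies beyond the scatter. Compound 3, `Cc1cc(C)cc(C(=O)Nc2cccc(-c3oc4cc(-c5ccc(F)cc5)ccc4c(=O)c3O)c2)c1`, is not yet measured. It differs from compound 2 in this: 3,5-dimethylphenyl in place of 3,5-dimethoxyphenyl on a carbonyl carbon. Among the compounds with values here, only the step from compound 1 to compound 2 bears on this change, and it was modest. Compound 3 carries two methyl groups where compound 1 carried one and compound 2 carried two methoxy groups, so its number is expected to fall between those two, probably nearer compound 1. Compound 3 is therefore estimated at 4500 nM in this assay, within 2000 nM to 10000 nM, a step of a 1.7-fold higher number from compound 2 to compound 3 (0.22 log units; within the scatter) that is expected to be small and possibly within the scatter.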

Compound 3, half-maximal inhibitory concentration: 5540 nM
Beside the measured number, compound 3's estimate is 1.2-fold (0.09 log units) below it, within the range that was stated.
By their numbers in this assay, from the lowest: compound 2; then compounds 3 and 1 (each within the scatter of the next).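

In this assay the exchange of 3,5-dimethoxyphenyl for 3,5-dimethylphenyl on the amide carbonyl carbon gives a 2.1-fold higher number from compound 2 to compound 3 (0.31 log units; beyond the scatter) and a modest step, whereas adding a second methyl group gives a 1.2-fold lower number from compound 1 to compound 3 (0.08 log units; within the scatter) and stays within the scatter. Among these three compounds the difference therefore follows the methoxy groups and not the presence of a second group on the ring, with compound 2 alone standing apart from the two methyl-bearing compounds. Nothing measured here offers an explanation for this difference.

The compounds shown leave open whether a single methoxy group would suffice or whether both are needed. They also leave open how a hydroxyl, an amine or a chlorine in the same places on the ring would compare with the methoxy groups of compound 2.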